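Cytotoxicity of an aryl ether series on Vero cells

The source may hold more compounds than are shown below. What is called first, only, known or untested is meant among the compounds shown, and "the series" means these compounds.

The measure here is an ADME assay on Vero cells (Chlorocebus sabaeus) for cytotoxicity, read by sulforhodamine B assay, with a stated time of 72 h; on this read-out higher numbers stand for weaker inhibition and lower numbers for stronger inhibition. Compound 1 `COc1ccc2c(c1)[C@@H](O)CN(C)C2` carries a methoxy group on its core. In this assay compound 1 gives > 100000 nM, which is a limit of the assay rather than a number. Compound 1 therefore stands at the limit of > 100000 nM in this assay, at which 1 of the 3 values shown sits, the weaker end of what was recorded. Compound 2 `CN1Cc2ccc(OCc3ccc(-c4ccccc4)cc3)cc2[C@@H](O)C1` gives 23000 nM in this assay. Compound 3 `CN1Cc2ccc(OCCCn3ccnc3[N+](=O)[O-])cc2[C@@H](O)C1` gives > 50000 nM in this assay, and this too is a limit, namely (the limit of > 50000 nM in this assay, at which 1 of the 3 values shown sits).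

Compound 4 `CN1Cc2ccc(OCc3cccc(Br)c3)cc2[C@@H](O)C1` is not yet measured. It differs from compound 1 by 3-bromophenyl in place of hydrogen on a saturated chain carbon bound to an oxygen on an aromatic ring. No measured pair differs in a single place, so the size of this step is not shown; compound 2, whose ether carries a larger aromatic group, gives the only numerical value, and compound 4 is expected to move in the same direction, toward stronger inhibition, by a step beyond the scatter though smaller than the gap to compound 2. The expected step is an at least 2.5-fold lower number from compound 1 to compound 4 (0.39 log units; beyond the scatter). Compound 4 is estimated at 40000 nM, within 15000 nM to 100000 nM.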

Compound 4, half-maximal inhibitory concentration: 60300 nM
Beside the measured number, compound 4's estimate is 1.5-fold (0.18 log units) below it; low and high end bracket the measured number.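

Going by these compounds alone, compound 4 gives the first step between measured compounds that differ in one place: 3-bromophenyl in place of hydrogen on a saturated chain carbon bound to an oxygen on an aromatic ring gives an at least 1.6-fold lower number from compound 1 to compound 4 (0.21 log units; that floor lies within the scatter) in this assay. This shows that the position carries this aromatic group with a measured number as the result, although the floor of the step does not by itself establish a change beyond the scatter. The step has a floor and no upper end because compound 1 is a limit of the assay: the limit of > 100000 nM in this assay, at which 1 of the 4 values shown sits.

Going by these compounds, it remains open whether the bromine or the ring itself accounts for the step. An unsubstituted phenyl, a pyridine ring or a carboxylic acid on the same carbon would each test this position further.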